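The source may report more compounds than this note shows. Statements on the series, on what has been measured and on what is new or still open speak of the compounds shown alone.

Measured in a physicochemical assay for solubility, measured as kinetic solubility; on this read-out higher numbers stand for higher solubility and lower numbers for lower solubility:
- Compound 1 `O=C(Nc1ccnnc1)c1cc(C(F)(F)F)ccc1OCc1ccccc1`: < 1000 nM (a limit)
- Compound 2 `O=C(Nc1cccc(Cl)c1)c1cc(C(F)(F)F)ccc1OCc1ccccc1`: 7000 nM
- Compound 3 `O=C(Nc1cccc(F)c1)c1cc(C(F)(F)F)ccc1OCc1ccc(F)cc1`: < 1000 nM (a limit)

Compound 3 has no exact number and stands at the limit of < 1000 nM in this assay, at which 2 of the 3 values shown sit. Its true value could lie anywhere under that limit, so any step away from compound 3 has an uncertain starting point.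

Compound 4 `N#Cc1cccc(NC(=O)c2cc(C(F)(F)F)ccc2OCc2ccc(F)cc2)c1` has cyano in place of fluoro on an aromatic carbon, so 3-fluorophenyl becomes 3-cyanophenyl: cyano in place of fluoro on an aromatic carbon.

Among the measured compounds shown here, no measured step makes this same swap. The nearest evidence is an at least 7.0-fold higher number from compound 1 to compound 2 (0.84 log units; beyond the scatter). That step exchanges the entire group on an amide-type nitrogen, with 3-chlorophenyl in place of pyridazin-4-yl, and so it is a much larger change than the one considered here. For the measured compounds named here, it shows that this assay can move clearly, and compound 2 at 7000 nM gives the only true number so far. It says little about a single substituent swap, however, so no step beyond the usual scatter is expected, although a small rise could bring a number into view. The expected step is a number no lower from compound 3 to compound 4 (the limit leaves the size open).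

The estimate for compound 4 is 1000 nM, with an expected range from 400 nM to 4000 nM.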

Compound 4, solubility: < 1000 nM
Compound 4: only a limit was reported (the forecaster's own chance of this, stated with the estimate: 60%); the middle value sits exactly at the limit.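

In this assay, compound 4 gives only a limit, as compound 3 does, so no step between compound 3 and compound 4 can be read: the limit of < 1000 nM in this assay, at which 3 of the 4 values shown sit.

The compounds shown leave open whether cyano in place of fluoro on this aromatic ring changes the true solubility of compound 3 at all, and in which direction.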